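The source may hold more compounds than are shown below. What is called first, only, known or untested is meant among the compounds shown, and "the series" means these compounds.

For the measured compounds named here, compound 1 `COc1ccc(/C=C2/CN(C)/C(=N/c3ccc(OC)cc3)S2)cc1` is the only compound here with a plain number in an ADME assay on TERT-RPE1 cells (Homo sapiens) for cytotoxicity, read by MTT assay, with a stated time of 72 h; a higher number here means a weaker inhibitor, a lower number a stronger inhibitor: compound 1 gives 65900 nM. Compound 2 `COc1ccc(/C=C2\S/C(=N\c3cc(C(F)(F)F)cc(C(F)(F)F)c3)N(C)C2=O)cc1` reaches only a limit of the assay, > 100000 nM, which is the case described by the limit of > 100000 nM in this assay, at which 1 of the 2 values shown sits. Compound 3 `COc1ccc(/C=C2/CN(C)/C(=N/c3ccc([N+](=O)[O-])cc3)S2)cc1` has not yet been tested and differs from compound 1 by nitro in place of methoxy on an aromatic carbon. Going by the values given here, no measured pair shows this change, so only a small step is expected in this assay, toward modestly stronger inhibition or none beyond the scatter: a 1.5-fold lower number from compound 1 to compound 3 (0.17 log units; within the scatter). Compound 3 is therefore estimated at 45000 nM, with a range from 15000 nM to 100000 nM.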

Compound 3, half-maximal inhibitory concentration: > 100000 nM
Compound 3: only a limit was reported; the forecaster's own chance of this, stated with the estimate: 25%; at least 2.2-fold (0.34 log units) between middle value and limit.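

In this assay, for the compounds shown here, nitro in place of methoxy on this aromatic carbon gives an at least 1.5-fold higher number from compound 1 to compound 3 (0.18 log units; that floor lies within the scatter), the first reading of this change, and it shows no sign of stronger inhibition. Compound 3 gives > 100000 nM, which is a limit, so the step is only a floor and does not establish a real difference. Its true size stays unknown because the readings stop there: the limit of > 100000 nM in this assay, at which 2 of the 3 values shown sit.

From the compounds shown here alone, how far compound 3 lies past that limit stays open. So does whether an amine or a carboxylic acid on the same aromatic carbon would bring the number down.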